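A Hydroxy Group Added to an Oxazolidinone Aryl Ether

The source may report more compounds than this note shows. Statements on the series, on what has been measured and on what is new or still open speak of the compounds shown alone.

Two compounds carry a measurement in an assay on HEK293 cells for inhibition of N-acylethanolamine-hydrolyzing acid amidase (Rattus norvegicus), read by LC-MS, with a stated time of 30 min; on this read-out lower numbers stand for stronger inhibition and higher numbers for weaker inhibition. Compound 1, `O=C(O)c1ccc(CCCCCC(=O)N2CCOC2=O)cc1`, reaches only the limit of the assay, reported as > 20000 nM, and so gives no number. That limit is the one described as the limit of > 20000 nM in this assay, at which 1 of the 2 values shown sits. Among the compounds with values here, compound 2, `O=C1OCCN1C(=O)c1ccc(Oc2ccccc2)cc1`, is the single compound with a number, and in this assay compound 2 gives 680 nM. Compound 2 thus stands as the only numeric point of reference here. Compound 3, `O=C1OCCN1C(=O)c1ccc(Oc2ccc(O)cc2)cc1`, differs from compound 2 by the change (hydroxy in place of hydrogen on an aromatic carbon), that is, hydroxy in place of hydrogen on an aromatic carbon. No measured pair of this kind is shown, so the size of the step can only be expected. The author expects the step of a 1.5-fold higher number from compound 2 to compound 3 (0.17 log units; within the scatter) to be small, near the scatter and leaning toward weaker inhibition. Compound 3 is therefore estimated at 1000 nM, with a range from 300 nM to 4000 nM.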

Compound 3, half-maximal inhibitory concentration: > 20000 nM
Compound 3: no number, only a limit; the forecaster's own chance of this, stated with the estimate: 5%; at least 20-fold (1.30 log units) between middle value and limit.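

In this assay, the outer ring of compound 2 turns out not to tolerate every small change: hydroxy in place of hydrogen on an aromatic carbon, para to a large group, brings an at least 29-fold higher number from compound 2 to compound 3 (1.46 log units; beyond the scatter). Within the data shown here, this single added oxygen is enough to produce a large step, which the earlier compounds could not show, as no measured pair stood among them. Compound 3 gives only a limit and not a number, and that limit now holds for most of the compounds shown: the limit of > 20000 nM in this assay, at which 2 of the 3 values shown sit.

Going by these compounds, whether the step belongs to the hydroxy group itself or would follow any group at this carbon stays open, and a methoxy group or a fluorine atom in the same place would bear on that. Also open, on these data alone, is how a hydroxy group would read on another carbon of this ring.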